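Benzisoxazole carboxylic acid series: amide to phenyl swap

A few compounds are considered here, and "the series" means these few. Any claim that something is new, unique, unknown or untested is made for them only; others in the source may bear on it.

Measured so far:
- compound 1, `CC(C)C(=O)Nc1ccc(-c2onc3ccc(C(=O)O)cc23)cc1`: 820 nM
- compound 2, `O=C(O)c1ccc2noc(-c3cccc(C(F)(F)F)c3)c2c1`: 1460 nM
- compound 3, `O=C(O)c1ccc2noc(-c3cccc(NC(=O)C4CC4)c3)c2c1`: 410 nM

All three values come from an assay for inhibition of inositol hexakisphosphate kinase 2 (Homo sapiens), read by colorimetric assay, coupled enzyme assay and malachite green, with a stated time of 120 min, in the presence of a further agent that is not named here; a lower number here means a stronger inhibitor, a higher number a weaker inhibitor. Compound 3 gives the lowest number of the three, but its gap to compound 1 lies within the usual scatter, so the two cannot be separated on these data. Among the measured compounds shown here, only compound 2 stands clearly apart: the single comparable step is a 3.6-fold lower number from compound 2 to compound 3 (0.55 log units; beyond the scatter).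

Compound 4, `O=C(O)c1ccc2noc(-c3cccc(-c4ccccc4)c3)c2c1`, is the next in line. Against compound 3 the change is phenyl in place of (cyclopropylcarbonyl)amino on an aromatic carbon. For the measured compounds named here, no measured step covers this exchange: the one step available swaps trifluoromethyl for the amide, and compound 1 carries a different amide on the same ring. Since the amide-bearing compound 3 sits at the low end and the amide-free compound 2 at the high end, removing the amide in favour of phenyl is expected to move the number upward, by a modest amount, though this rests on a single step and could also fall within the scatter.

For compound 4 the expected value in this assay is 1200 nM, with a range of 400 nM to 4000 nM, which corresponds to an estimated 2.9-fold higher number from compound 3 to compound 4 (0.47 log units; beyond the scatter).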

Compound 4, half-maximal inhibitory concentration: 130 nM
For compound 4 the middle estimate is 9.2-fold (0.97 log units) above the measured one; measured number outside the range, below it.
By their numbers in this assay, from the lowest: compound 4; then compounds 3, 1 and 2 (each within the scatter of the next, the first and the last beyond it).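

At this position on the aromatic ring, the amide is not needed for a low number in this assay: phenyl in place of (cyclopropylcarbonyl)amino gives a 3.2-fold lower number from compound 3 to compound 4 (0.50 log units; beyond the scatter), so a group with 0 hydrogen-bond donors and 0 hydrogen-bond acceptors outperforms one that has both. The earlier step had only shown that the amide improves on trifluoromethyl; replacing trifluoromethyl with phenyl gives a much larger change, an 11-fold lower number from compound 2 to compound 4 (1.05 log units; beyond the scatter), and ranks this position's three groups as phenyl, then (cyclopropylcarbonyl)amino, then trifluoromethyl. No supporting measurements bear on why phenyl performs better here.

The compounds shown do not separate the contribution of the aromatic ring from that of the group's size, a question that cyclohexyl or pyridyl at this position, or a phenyl ring carrying an amine or methoxy group, would address. On these data alone, it also remains open whether the carboxylic acid of the shared core can give way to a tetrazole or a primary amide while phenyl stays in place.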